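Removing the pyrazole methyl: expected antiproliferative effect

The source may hold more compounds than are shown below. What is called first, only, known or untested is meant among the compounds shown, and "the series" means these compounds.

Of the compounds shown here, two have been measured. Compound 1 `O=C1/C(=C\Nc2cc(-c3ccco3)[nH]n2)C(c2ccccc2)=NN1c1ccccc1` gives 13400 nM in a functional assay on MDA-MB-361 cells (Homo sapiens) for antiproliferative activity, read by MTT assay, with a stated time of 72 h; on this read-out higher numbers stand for weaker inhibition and lower numbers for stronger inhibition. Compound 2 `Cc1cc(N/C=C2\C(=O)N(c3ccccc3)N=C2c2ccccc2)n[nH]1` gives 9980 nM in this assay; of the two numbers it stands nearest to compound 1, and the two lie within the usual scatter of each other. For the measured compounds named here, the single measured step, a 1.3-fold lower number from compound 1 to compound 2 (0.13 log units; within the scatter), puts methyl in place of furan-2-yl on an aromatic carbon and stays within the scatter. Compound 3 `O=C1/C(=C\Nc2cc[nH]n2)C(c2ccccc2)=NN1c1ccccc1` carries the change (hydrogen in place of methyl on an aromatic carbon), hydrogen in place of methyl on an aromatic carbon, turning (5-methyl-1H-pyrazol-3-yl)amino into (1H-pyrazol-3-yl)amino. Going by the values given here, the only step that bears on this, that between compound 1 and compound 2 in this assay, trimmed the group at this same aromatic carbon without moving the number beyond the scatter, so no step beyond the scatter is expected here either. Compound 3 is therefore expected to give about 9000 nM, between 4000 nM and 20000 nM, in this assay. The expected step is a 1.1-fold lower number from compound 2 to compound 3 (0.04 log units; within the scatter).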

Compound 3, half-maximal inhibitory concentration: 51000 nM
Compound 3: middle estimate off by 5.7-fold (0.75 log units), on the low side; measured number above the stated range.
By their numbers in this assay, from the lowest: compounds 2 and 1 (each within the scatter of the next); then compound 3.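

In this assay this aromatic carbon of the 1H-pyrazol-3-yl group proves sensitive to substitution, which the step between compound 1 and compound 2 alone did not show: removing the methyl gives a 5.1-fold higher number from compound 2 to compound 3 (0.71 log units; beyond the scatter) and removing the furan-2-yl gives a 3.8-fold higher number from compound 1 to compound 3 (0.58 log units; beyond the scatter) in the same direction. Among these three compounds, both substituents go with lower numbers than hydrogen, while methyl and furan-2-yl remain within the scatter of each other. Nothing available explains this difference.

Still open, from the compounds shown here alone, is whether a carbon substituent is needed here, or whether an amine, a chlorine atom or a longer chain such as propyl would serve as well. Also open, going by these compounds, is whether any group at this carbon can give a number beyond the scatter below that of compound 2 .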